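The source may hold more compounds than are shown below. What is called first, only, known or untested is meant among the compounds shown, and "the series" means these compounds.

Compound 1 `C=CCOc1cc(OC)c(C(=O)/C=C/c2ccc(F)cc2)c(OCC=C)c1` and compound 2 `C=CCOc1cc(OC)c(C(=O)/C=C/c2ccc(O)cc2)c(OCC=C)c1` share one core and differ only at the aromatic carbon where compound 1 carries fluoro and compound 2 hydroxy. Among the measured compounds shown here, in an ADME assay on Vero cells (Chlorocebus sabaeus) for cytotoxicity, read by MTT assay (a lower number here means a stronger inhibitor, a higher number a weaker inhibitor), compound 1 gives 13600 nM, and in this assay compound 2 gives 76400 nM, the higher of the two numbers measured so far; the one step measured between them, a 5.6-fold higher number from compound 1 to compound 2 (0.75 log units; beyond the scatter), is the only step recorded. Compound 3 `C=CCOc1cc(OC)c(C(=O)/C=C/c2ccc(Cl)cc2)c(OCC=C)c1` is compound 2 changed in one place: chloro in place of hydroxy on an aromatic carbon. The change bears on the measured step in reverse, since it removes the hydroxy that compound 2 gained in a 5.6-fold higher number from compound 1 to compound 2 (0.75 log units; beyond the scatter) and puts a halogen back, as in compound 1. The number expected for compound 3 in this assay is therefore a step downward of about the same size, a 5.1-fold lower number from compound 2 to compound 3 (0.71 log units; beyond the scatter), and compound 3 is estimated at 15000 nM, with a range from 6000 nM to 40000 nM.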

Compound 3, half-maximal inhibitory concentration: 10400 nM
Compound 3: middle estimate off by 1.4-fold (0.16 log units), on the high side; the measured number falls inside the stated range.
By their numbers in this assay, from the lowest: compounds 3 and 1 (each within the scatter of the next); then compound 2.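

In this assay, the exchange of hydroxy for chloro gives a 7.3-fold lower number from compound 2 to compound 3 (0.87 log units; beyond the scatter), so a second halogen now stands apart from hydroxy at this aromatic carbon, as fluoro did. Chloro in place of fluoro gives a 1.3-fold lower number from compound 1 to compound 3 (0.12 log units; within the scatter), and the two halogens therefore cannot be told apart here, leaving hydroxy as the one group of the three that separates from the others. No evidence is available on what underlies this separation.

From the compounds shown here alone, whether an amine, a methoxy group or a carboxylic acid on this carbon would fall with hydroxy or with the halogens remains open, as does the place of bromo. Also open, going by these compounds, is whether the step from 4-hydroxyphenyl to 4-chlorophenyl would keep its size on a different core.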